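Benzoxazolyl and benzothiazolyl piperazine oxadiazole thioethers on breast cancer cells

A few compounds are considered here, and "the series" means these few. Any claim that something is new, unique, unknown or untested is made for them only; others in the source may bear on it.

Measured so far:
compound 1 `c1ccc(-c2nnc(SCCCN3CCN(c4nc5ccccc5o4)CC3)o2)cc1`, 117000 nM
compound 2 `O=C(NCc1nnc(SCCCN2CCN(c3nc4ccccc4o3)CC2)o1)c1ccccc1`, 52700 nM
compound 3 `c1ccc(-c2nnc(SCCCN3CCN(c4nc5ccccc5s4)CC3)o2)cc1`, 76900 nM

All three were read in a functional assay on MCF7 cells (Homo sapiens) for inhibition, read by MTT assay, with a stated time of 72 h; on this read-out higher numbers stand for weaker inhibition and lower numbers for stronger inhibition. Compound 1 gives 117000 nM, compound 2 gives 52700 nM and compound 3 gives 76900 nM. Compound 2 is derived from compound 1 by benzamidomethyl in place of phenyl on an aromatic carbon; this gave a 2.2-fold lower number from compound 1 to compound 2 (0.35 log units; beyond the scatter). Compound 3 is derived from compound 1 by 1,3-benzothiazol-2-yl in place of 1,3-benzoxazol-2-yl on an amine nitrogen in a ring; this gave a 1.5-fold lower number from compound 1 to compound 3 (0.18 log units; within the scatter), so compound 1 and compound 3 cannot be ordered against each other.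

Compound 4 `O=C(NCc1nnc(SCCCN2CCN(c3nc4ccccc4s3)CC2)o1)c1ccccc1` is not yet measured. It differs from compound 3 by benzamidomethyl in place of phenyl on an aromatic carbon. The place described for this change is word for word the place described for the change from compound 1 to compound 2, so the two changes are the same; what differs between the pair is only the core, which is the difference just given between compound 1 and compound 3.

Among the measured compounds shown here, only one instance of this change has a number behind it, so the expectation for compound 4 rests on a single step. In this assay compound 4 is expected to show a 2.2-fold lower number from compound 3 to compound 4 (0.34 log units; beyond the scatter), because the same change gave a 2.2-fold lower number from compound 1 to compound 2 (0.35 log units; beyond the scatter). For the measured compounds named here, compound 4 is estimated at 35000 nM, with a range from 15000 nM to 80000 nM expected to hold most repeats, the width reflecting that one step on a different core is the only guide.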

Compound 4, half-maximal inhibitory concentration: 39000 nM
For compound 4 the middle estimate is 1.1-fold (0.05 log units) below the measured one; measured number inside the range.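

In this assay, benzamidomethyl in place of phenyl on the core bearing 1,3-benzothiazol-2-yl gives a 2.0-fold lower number from compound 3 to compound 4 (0.29 log units; within the scatter), and this step agrees with the one on the core bearing 1,3-benzoxazol-2-yl: the same change on two cores in this assay, a 2.2-fold lower number (0.35 log units; beyond the scatter) from compound 1 to compound 2 and a 2.0-fold lower number (0.29 log units; within the scatter) from compound 3 to compound 4, 1.1-fold (0.05 log units) apart, within the scatter of two such steps

Read the other way round, 1,3-benzothiazol-2-yl in place of 1,3-benzoxazol-2-yl gives a 1.4-fold lower number from compound 2 to compound 4 (0.13 log units; within the scatter), and this change also carries over from one core to the other: the same change on two cores in this assay, a 1.5-fold lower number (0.18 log units; within the scatter) from compound 1 to compound 3 and a 1.4-fold lower number (0.13 log units; within the scatter) from compound 2 to compound 4, 1.1-fold (0.05 log units) apart, within the scatter of two such steps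

Within these four compounds the two changes therefore combine without a detectable dependence on each other, but this is a single set of four compounds on one cell line, so it does not show that either change would transfer to other cores, and the steps printed as within the scatter do not by themselves order the compounds they join.

The compounds shown leave open whether the amide in benzamidomethyl matters, since a plain benzyl group in the same place would be needed to separate the amide from the added chain. They also leave open how a longer chain in place of the thioether linker, or an amine or a carboxylic acid on the phenyl ring, would read in this assay.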